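Solubility of a 2-aminothienopyrimidine series: piperidine to oxane

The compounds below may be only part of what the source reports. "The series", "measured", "known", "first", "only" and "open" are said of these compounds alone.

Measured compounds, solubility in phosphate buffer:
compound 1, `CN(C)CCCNc1nc(N)nc2cc(-c3ccc(C(F)(F)F)cc3)sc12`: 148 ug/mL
compound 2, `CS(=O)(=O)c1ccc(-c2nc(N3CCNCC3)nc3cc(-c4ccc(C(F)(F)F)cc4)sc23)cc1`: < 5 ug/mL
compound 3, `Nc1nc(NC2CCCNC2)c2sc(-c3ccc(C(F)(F)F)cc3)cc2n1`: 125 ug/mL

In a physicochemical assay for solubility, in phosphate buffer, at pH 6.5 (on this read-out lower numbers stand for lower solubility and higher numbers for higher solubility), compound 3 gives 125 ug/mL. Compound 1 gives 148 ug/mL, and the step of a 1.2-fold lower number from compound 1 to compound 3 (0.07 log units; within the scatter). For compound 2 this assay reports only a limit, < 5 ug/mL, as noted in the limit of < 5 ug/mL in this assay, at which 1 of the 3 values shown sits.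

Compound 4, `Nc1nc(NC2CCOCC2)c2sc(-c3ccc(C(F)(F)F)cc3)cc2n1`, differs from compound 3 by oxan-4-yl in place of piperidin-3-yl on a nitrogen on an aromatic ring. For the measured compounds named here, only one measured step bears on this position, a 1.2-fold lower number from compound 1 to compound 3 (0.07 log units; within the scatter), and it swapped one nitrogen-bearing side chain for another, whereas here the ring nitrogen leaves and an oxygen enters. Going by the values given here, that step gives no guidance on such a change, so the expected direction rests on no measured precedent; a modest fall is estimated, with wide uncertainty. Compound 4 is therefore expected at 35 ug/mL, between 8 ug/mL and 130 ug/mL, a step of a 3.6-fold lower number from compound 3 to compound 4 (0.55 log units; beyond the scatter).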

Compound 4, solubility: < 5 ug/mL
Compound 4: only a limit was reported; the forecaster's own chance of this, stated with the estimate: 15%; middle value at least 7.0-fold (0.84 log units) away from the limit.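

The side chain on this nitrogen matters in this assay: the nitrogen-bearing chains of compound 1 and compound 3 read within the scatter of each other, yet oxan-4-yl gave an at least 25-fold lower number from compound 3 to compound 4 (1.39 log units; beyond the scatter) and an at least 29-fold lower number from compound 1 to compound 4 (1.47 log units; beyond the scatter). So exchanging the ring nitrogen of piperidin-3-yl for the oxygen of oxan-4-yl is no neutral swap at this place. The value of compound 4 is only a limit: the limit of < 5 ug/mL in this assay, at which 2 of the 4 values shown sit.

The compounds shown leave open whether the loss of the ring nitrogen or the change of attachment point counts. On these data alone, how a piperidin-4-yl group would read also remains open.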